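The source may hold more compounds than are shown below. What is called first, only, known or untested is meant among the compounds shown, and "the series" means these compounds.

Measured so far:
compound 1, `COc1ccc(-c2nc(C)c(C(=O)CSc3nc(-c4ccc(OC)cc4)c(C#N)c(=O)[nH]3)s2)cc1`, 97%
compound 2, `Cc1nc(-c2ccc(Cl)cc2)sc1C(=O)CSc1nc(-c2cccc(Cl)c2)c(C#N)c(=O)[nH]1`, 80.2%

Both were tested in a functional assay on U-87MG ATCC cells for antiproliferative activity against U-87 MG (Homo sapiens), read by MTT assay, with a stated time of 48 h, tested at 5 uM; a lower number here means a stronger effect, a higher number a weaker effect of the compound at the concentration tested. Compound 1 gives 97% in this assay, while compound 2 gives 80.2%, the lower of the two numbers; the gap between them lies beyond the usual scatter, so compound 2 shows the stronger effect of the pair. The next compound, compound 3 `COc1ccc(-c2nc(C)c(C(=O)CSc3nc(-c4cccc(Cl)c4)c(C#N)c(=O)[nH]3)s2)cc1`, has not yet been measured. It differs from compound 2 in one place: methoxy in place of chloro on an aromatic carbon. Compound 1 carries methoxy on both of its outer rings and gives the higher number, so compound 3 stands between the two measured compounds in structure. For the measured compounds named here, no step between measured compounds that differ only in this way is known, so the expectation rests on this comparison alone. A step of a number 7.8 percentage points higher from compound 2 to compound 3 (within the scatter) is expected, a modest move toward a weaker effect that may not exceed the scatter. Compound 3 is therefore estimated at 88%, with a range from 75% to 100%.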

Compound 3, a percentage reported as activity, at one concentration (the size of the read-out at that concentration, not a potency): 95.7%
Beside the measured number, compound 3's estimate is 7.7 percentage points below it, within the range that was stated.
By their numbers in this assay, from the lowest: compound 2; then compounds 3 and 1 (each within the scatter of the next).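

In this assay, methoxy in place of chloro on the ring that turns 4-chlorophenyl into 4-methoxyphenyl gives a number 15.5 percentage points higher from compound 2 to compound 3 (beyond the scatter), so at this position chloro goes with the stronger effect. The first two compounds differ in more than one place and could not isolate this single change. On the other outer ring, 3-chlorophenyl in place of 4-methoxyphenyl gives a number 1.3 percentage points lower from compound 1 to compound 3 (within the scatter), a step that does not separate the two compounds. No measurement shown gives a reason for either step.

From the compounds shown here alone, what an amine or a carboxylic acid would do in place of chloro at this position remains open. Also open, going by these compounds, is whether chloro keeps its edge over methoxy when the other outer ring carries a different group, such as a fluoro or a longer alkoxy chain.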